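Working notes: the step from compound 2 to compound 3

The source may hold more compounds than are shown below. What is called first, only, known or untested is meant among the compounds shown, and "the series" means these compounds.

Measured in a functional assay on HCT-116 cells (Homo sapiens) for cytotoxicity, read by MTT assay, with a stated time of 48 h; on this read-out higher numbers stand for weaker inhibition of growth and lower numbers for stronger inhibition of growth:

compound 1 `Cc1nc2cc(Cl)c(Cl)cc2[nH]1`: 51000 nM
compound 2 `Cc1nc2cc(Cl)c(Cl)cc2n1C1CCCC1`: 13000 nM

Going by the values given here, compound 2 has the lowest of the two numbers; its nearest neighbour is compound 1, and the only measured step, a 3.9-fold lower number from compound 1 to compound 2 (0.59 log units; beyond the scatter), concerns cyclopentyl in place of hydrogen on an aromatic nitrogen.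

Compound 3 `CC(C)c1nc2cc(Cl)c(Cl)cc2n1C1CCCC1` differs from compound 2 as follows: isopropyl in place of methyl on an aromatic carbon. No measured step touches this place, so nothing shown bears on the change. The step of a 1.3-fold lower number from compound 2 to compound 3 (0.11 log units; within the scatter) is therefore expected to stay within the scatter. Compound 3 is estimated at 10000 nM, with a range of 3500 nM to 28000 nM.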

Compound 3, concentration for 50% growth inhibition: 9000 nM
Compound 3: the middle estimate sits 1.1-fold (0.05 log units) above what was measured; the measured number falls inside the stated range.
By their numbers in this assay, from the lowest: compounds 3 and 2 (each within the scatter of the next); then compound 1.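

Going by these compounds alone, this is the first measured change on the aromatic carbon between two ring nitrogen atoms: in this assay, isopropyl in place of methyl gives a 1.4-fold lower number from compound 2 to compound 3 (0.16 log units; within the scatter). With cyclopentyl held constant, this change therefore does not separate compound 3 from compound 2. No supporting evidence bears on the result.

Going by these compounds, whether an amine, a carboxylic acid or a longer chain on this carbon would move the number beyond the scatter remains open. Also open, on these data alone, is whether isopropyl gives a similar result with hydrogen in place of cyclopentyl on the aromatic nitrogen.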